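A few compounds are considered here, and "the series" means these few. Any claim that something is new, unique, unknown or untested is made for them only; others in the source may bear on it.

In a functional assay on MCF7 cells (Homo sapiens) for cytotoxicity, read by MTT assay, with a stated time of 72 h (on this read-out higher numbers stand for weaker inhibition and lower numbers for stronger inhibition), three compounds have been measured:
- compound 1 `COc1ccc(/C=C2\CCC/C(=C\c3cccc(Cl)c3)C2=O)cc1OC` gives 6000 nM
- compound 2 `COc1ccccc1/C=C1\CCC/C(=C\c2ccc(OC)c(OC)c2)C1=O` gives 8000 nM
- compound 3 `COc1ccc(/C=C2\CCC/C(=C\c3ccc(O)cc3)C2=O)cc1OC` gives 17000 nM

Compound 3 has the highest number of the three, which makes it the weakest inhibitor here. Compound 4 `COc1cc(/C=C2\CCC/C(=C\c3ccc(OC)c(OC)c3)C2=O)ccc1O` differs from it by one change, methoxy in place of hydrogen on an aromatic carbon, ortho to a hydroxy group (methoxy in place of hydrogen on an aromatic carbon), so 4-hydroxyphenyl becomes 4-hydroxy-3-methoxyphenyl. For the measured compounds named here, no measured step makes this exact change. The closest evidence is that bringing in 4-hydroxyphenyl went with a higher number twice, a 2.8-fold higher number from compound 1 to compound 3 (0.45 log units; beyond the scatter) and a 2.1-fold higher number from compound 2 to compound 3 (0.33 log units; beyond the scatter), both modest. A similarly modest move towards stronger inhibition is therefore expected, a 1.7-fold lower number from compound 3 to compound 4 (0.23 log units; within the scatter) (an estimate). For compound 4 the estimated value is 10000 nM (range 4000 nM to 22000 nM).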

Compound 4, half-maximal inhibitory concentration: 7900 nM
Beside the measured number, compound 4's estimate is 1.3-fold (0.10 log units) above it; low and high end bracket the measured number.
By their numbers in this assay, from the lowest: compounds 1, 4 and 2 (each within the scatter of the next); then compound 3.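

Methoxy on this aromatic carbon, ortho to a hydroxy group, gives the first direct sign that the position responds to substitution: a 2.2-fold lower number from compound 3 to compound 4 (0.33 log units; beyond the scatter) is a modest move towards stronger inhibition. It also closes the gap opened by 4-hydroxyphenyl, as 4-hydroxy-3-methoxyphenyl stands level with 2-methoxyphenyl (a 1.0-fold lower number from compound 2 to compound 4 (0.01 log units; within the scatter)) and with 3-chlorophenyl (a 1.3-fold higher number from compound 1 to compound 4 (0.12 log units; within the scatter)). Nothing available explains why the number falls with this change.

On these data alone, whether methoxy itself matters, or any added group would do the same, stays open. Ethoxy, a longer chain, or an amine on this carbon would help to separate the two.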